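Three Aryl Esters at One Dose, and a Fourth

This account rests on a few compounds, and the source may have more. Where it says the series, first, only, none or still open, it means among the compounds named here.

Compound 1 `COc1cc(OC)c(OC)cc1/C=C/COC(=O)/C=C/c1ccc(Br)cc1`: 100%
Compound 2 `COc1cc(OC)c(OC)cc1/C=C/COC(=O)/C=C/c1ccccc1Cl`: 100%
Compound 3 `COc1cccc(/C=C/C(=O)OC/C=C/c2cc(OC)c(OC)cc2OC)c1`: 100%

In a functional assay on the whole organism (strain Kunming) with Mus musculus as the target, with a stated time of 0.5 h, at a dose of 100 mg/kg by the intraperitoneal route (on this read-out lower numbers stand for a stronger effect and higher numbers for a weaker effect at the one dose given), compound 1 gives 100%. Compound 2 gives 100%, and compound 3 gives 100%. All three share one core and differ only in the aryl group on a double-bonded chain carbon bound to a double-bonded chain carbon. The steps between them are no change at the digits printed from compound 1 to compound 2 (within the scatter), no change at the digits printed from compound 1 to compound 3 (within the scatter) and no change at the digits printed from compound 2 to compound 3 (within the scatter). Compound 3 therefore stands level with compound 1 and compound 2 in this assay.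

Compound 4 `COc1ccc(/C=C/C(=O)OC/C=C/c2cc(OC)c(OC)cc2OC)cc1` is not yet measured. It differs from compound 3 in one place: 4-methoxyphenyl in place of 3-methoxyphenyl on a double-bonded chain carbon bound to a double-bonded chain carbon

Each of the three measured steps swapped one aryl group for another at this same place, and none of them moved the read-out beyond the scatter. The change from compound 3 to compound 4 is of the same kind, so no step beyond the scatter is expected: the estimated step is no change at the digits printed from compound 3 to compound 4 (within the scatter). Compound 4 is expected to give about 100% in this assay, with a range from 90% to 100%.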

Compound 4, a percentage reported as activity, at one dose (the size of the read-out at that dose, not a potency): 100%
Beside the measured number, compound 4's estimate shows no gap at the digits printed; low and high end bracket the measured number.
By their numbers in this assay, from the lowest: compounds 1, 2, 3 and 4 (each within the scatter of the next).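

In this assay, within the data shown here, the exchange of 3-methoxyphenyl for 4-methoxyphenyl on a double-bonded chain carbon bound to a double-bonded chain carbon gives no change at the digits printed from compound 3 to compound 4 (within the scatter) even though the two groups hold the same atoms joined differently, a kind of change that the earlier steps, which swapped one substituted aryl group for a differently substituted one, did not test on its own. Compound 4 also matches the two halogen-bearing compounds, with no change at the digits printed from compound 2 to compound 4 (within the scatter) for 4-methoxyphenyl in place of 2-chlorophenyl and no change at the digits printed from compound 1 to compound 4 (within the scatter) when methoxy replaces bromo on an aromatic carbon. Four aryl groups now share one read-out at this place, so at this single dose they cannot be ranked against each other.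

Still open, going by these compounds, is whether a group of another kind at this place, such as an amine, a carboxylic acid or a longer chain in place of the aryl ring, would shift the read-out at this dose. Nothing available explains why the read-out holds steady across these four aryl groups.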